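The source may hold more compounds than are shown below. What is called first, only, known or untested is meant among the compounds shown, and "the series" means these compounds.

Series notes. Compound 1 `O=C(/C=C/c1coc2cc(O)ccc2c1=O)NCc1ccccc1` carries the shared core with a free hydroxyl. In a functional assay on HeLa cells (Homo sapiens) for inhibition, read by MTT assay, with a stated time of 48 h (on this read-out higher numbers stand for weaker inhibition and lower numbers for stronger inhibition), compound 1 gives only a limit, > 100000 nM. Compound 2 `Cc1ccc(CNC(=O)/C=C/c2coc3cc(O)ccc3c2=O)cc1` likewise gives only a limit in this assay, > 100000 nM. The step that the two limits leave unreadable from compound 1 to compound 2 therefore cannot be sized, because both values sit at the limit of > 100000 nM in this assay, at which 2 of the 3 values shown sit. Among the measured compounds shown here, compound 3 `COc1ccc2c(=O)c(/C=C/C(=O)NCc3ccccc3)coc2c1` is the one compound with a number in this assay, 33400 nM, and the step of an at least 2.9-fold lower number from compound 1 to compound 3 (0.47 log units; beyond the scatter) is the single readable step in the set.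

Compound 4 `COc1ccc2c(=O)c(/C=C/C(=O)Nc3ccc(F)cc3)coc2c1` keeps the core of compound 3 and changes the amide substituent: 4-fluorophenyl in place of benzyl on an amide-type nitrogen. For the measured compounds named here, no measured step touches this nitrogen; the two measured steps concern the aromatic carbon and the aromatic oxygen, so neither gives a direct reading of the size of this change. Only the position of compound 3 itself, with 33400 nM, anchors the expectation. The estimate for compound 4 is therefore a step within the scatter, a 1.1-fold lower number from compound 3 to compound 4 (0.05 log units; within the scatter), with no direction favoured. Compound 4 is expected at about 30000 nM in this assay, with the range 10000 nM to 100000 nM, and the upper end of that range reaches the limit at which compound 1 and compound 2 sit.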

Compound 4, half-maximal inhibitory concentration: 9680 nM
Compound 4: middle estimate off by 3.1-fold (0.49 log units), on the high side; the whole stated range lies above it.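

In this assay, among the compounds shown here, the amide-type nitrogen now has a direct reading for the first time: with 4-fluorophenyl in place of benzyl, the series shows a 3.5-fold lower number from compound 3 to compound 4 (0.54 log units; beyond the scatter). The earlier readable step concerned the oxygen on the aromatic ring, so this result shows that the number also responds to the substituent on the nitrogen, at least on the core of compound 3. Benzyl and 4-fluorophenyl have the same heavy-atom count and each carries one six-membered aromatic ring of carbon only, yet the change from benzylamino to (4-fluorophenyl)amino alters both the link to the ring and the fluorine on it, and this single step reads the two together.

The compounds shown leave open how far each part contributes, and how a plain phenyl, or a phenyl bearing an amine or a carboxylic acid in place of the fluorine, would read on the same nitrogen. From the compounds shown here alone, whether the same change carries over to the hydroxyl core of compound 1 also stays open, and the values on that core give no reading of it: the limit of > 100000 nM in this assay, at which 2 of the 4 values shown sit.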